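Hydroxystilbene series: amino to methoxy on the second ring

This account rests on a few compounds, and the source may have more. Where it says the series, first, only, none or still open, it means among the compounds named here.

Compound 1 `Nc1ccccc1/C=C/c1ccccc1O` gives 39 ug/mL in a functional assay on MCF7 cells (Homo sapiens) for inhibition, read by MTT assay, with a stated time of 2 days; a lower number here means a stronger inhibitor, a higher number a weaker inhibitor. Compound 2 `COc1ccccc1/C=C/c1ccccc1O` gives 17.9 ug/mL; the change is methoxy in place of amino on an aromatic carbon, and the step is a 2.2-fold lower number from compound 1 to compound 2 (0.34 log units; beyond the scatter). Compound 3 `Nc1cccc(/C=C/c2ccccc2O)c1` gives 24.7 ug/mL; its distances to compound 2 and to compound 1 are both within the scatter, so no order among these is drawn. The difference between the cores of compound 3 and compound 1 is not broken down here.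

Compound 4 `COc1cccc(/C=C/c2ccccc2O)c1` is unmeasured. Its change from compound 3 is methoxy in place of amino on an aromatic carbon. This is the same kind of change as from compound 1 to compound 2, though there the methoxy sits ortho to the group of 9 heavy atoms and here meta to it. The expected step is a 2.1-fold lower number from compound 3 to compound 4 (0.31 log units; beyond the scatter), resting on a 2.2-fold lower number from compound 1 to compound 2 (0.34 log units; beyond the scatter) in this assay. Compound 4 is estimated at 12 ug/mL, between 6 ug/mL and 25 ug/mL.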

Compound 4, half-maximal inhibitory concentration: 18 ug/mL
Estimate against measurement, compound 4: 1.5-fold (0.18 log units) below; low and high end bracket the measured number.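

In this assay, methoxy in place of amino on the core of compound 3 gives a 1.4-fold lower number from compound 3 to compound 4 (0.14 log units; within the scatter), so on this core the change has no readable effect. Set beside the earlier step, this one does not differ from it: the same change on two cores in this assay, a 2.2-fold lower number (0.34 log units; beyond the scatter) from compound 1 to compound 2 and a 1.4-fold lower number (0.14 log units; within the scatter) from compound 3 to compound 4, 1.6-fold (0.20 log units) apart, within the scatter of two such steps. The two steps are compatible with one shared effect across both cores, but a pair of cores does not establish that the change carries over, and a small real step on the core of compound 3 is neither shown nor excluded.

From the compounds shown here alone, it remains open whether other groups in the same place, such as a nitrile, a carboxylic acid or a longer alkoxy chain, would give a step beyond the scatter on either core.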